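The source may report more compounds than this note shows. Statements on the series, on what has been measured and on what is new or still open speak of the compounds shown alone.

In an assay for inhibition of Caspase-8 (Homo sapiens) (a lower number here means a stronger inhibitor, a higher number a weaker inhibitor), compound 3, with the structure `CCC(C(=O)N[C@@H](CC(=O)O)C(=O)CSCc1ccccc1)n1ccnc(NCC2COc3ccccc3O2)c1=O`, gives 8220 nM. This is the lower of the two plain numbers available, but only just: compound 1, with the structure `CCC(C(=O)N[C@@H](CC(=O)O)C(C)=O)n1cc(C(C)(C)C)nc(NCc2nonc2C)c1=O`, gives 10000 nM, and the gap between the two lies within the scatter of repeated measurements, so the two cannot be told apart. Compound 2, with the structure `CCCCCCN(C)CNCC(=O)[C@H](CC(=O)O)NC(=O)C(CC)n1ccnc(NCc2nonc2C)c1=O`, gives > 10000 nM in this assay; that value is a limit of the assay and not a number (the limit of > 10000 nM in this assay, at which 1 of the 3 values shown sits). Compound 4, with the structure `CCC(C(=O)N[C@@H](CC(=O)O)C(=O)CSCc1ccccc1)n1ccnc(NCc2cc(C)no2)c1=O`, differs from compound 3 in one place: 3-methyl-1,2-oxazol-5-yl in place of 2,3-dihydro-1,4-benzodioxin-2-yl on a saturated chain carbon bound to a nitrogen on an aromatic ring. Within the data shown here, no measured pair shows what such a swap does on its own, so the expectation rests on the thin picture that all three measured compounds sit near the weak end of the range. The step from compound 3 to compound 4 in this assay is expected to be a 1.1-fold higher number from compound 3 to compound 4 (0.04 log units; within the scatter), a change not beyond the scatter. Compound 4 is therefore estimated at 9000 nM, with a likely range from 4000 nM to 25000 nM, and a fair chance that only a limit is reported.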

Compound 4, half-maximal inhibitory concentration: 3300 nM
The estimate for compound 4 lay 2.7-fold (0.44 log units) above the measured number; measured number outside the range, below it.
By their numbers in this assay, from the lowest: compound 4; then compounds 3 and 1 (each within the scatter of the next).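

In this assay, among these compounds, this is the first pair of measured compounds that differ only on the saturated chain carbon bound to a nitrogen on an aromatic ring, and replacing 2,3-dihydro-1,4-benzodioxin-2-yl with 3-methyl-1,2-oxazol-5-yl gives a 2.5-fold lower number from compound 3 to compound 4 (0.40 log units; beyond the scatter). The place therefore responds to the group it carries, with 3-methyl-1,2-oxazol-5-yl, the group of fewer heavy atoms, giving a lower number than 2,3-dihydro-1,4-benzodioxin-2-yl, though a single pair cannot show which part of the change matters. Nothing measured here bears on why the number moves. From the compounds shown here alone, it remains open how a plain phenyl ring or an amine would behave in this place. Going by these compounds, it also remains open whether the same swap gives a similar step when the rest of the molecule differs.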